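From 4-(tert-butoxy)phenyl to benzamidomethyl on the shared core

The source may hold more compounds than are shown below. What is called first, only, known or untested is meant among the compounds shown, and "the series" means these compounds.

Compound 1 `O=[N+]([O-])c1ccc(-c2nnc(SCCCN3CCN(c4nc5ccccc5s4)CC3)o2)cc1` and compound 2 `CC(C)(C)Oc1ccc(-c2nnc(SCCCN3CCN(c4nc5ccccc5s4)CC3)o2)cc1` share one core. In a functional assay on HepG2 cells (Homo sapiens) for inhibition, read by MTT assay, with a stated time of 72 h (a lower number here means a stronger inhibitor, a higher number a weaker inhibitor), compound 1 gives 93300 nM while compound 2 gives 202000 nM as the higher of the two numbers. For the measured compounds named here, the only measured step is a 2.2-fold higher number from compound 1 to compound 2 (0.34 log units; beyond the scatter) and it is modest, with tert-butoxy in place of nitro on an aromatic carbon.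

Compound 3 `O=C(NCc1nnc(SCCCN2CCN(c3nc4ccccc4s3)CC2)o1)c1ccccc1` carries a larger change, with benzamidomethyl in place of 4-(tert-butoxy)phenyl on an aromatic carbon of the five-membered aromatic ring with 2 nitrogen and 1 oxygen. Going by the values given here, the measured step bears on this only loosely, since it altered a group on the aromatic ring that leaves here and no measured compound carries benzamidomethyl. A modest move is therefore expected, towards compound 1 at 93300 nM and not further upward, with low confidence in the direction. The estimated change is a 1.6-fold lower number from compound 2 to compound 3 (0.21 log units; within the scatter) on present data. For compound 3 the expected value is 125000 nM with an estimated range of 45000 nM to 300000 nM for repeated measurements.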

Compound 3, half-maximal inhibitory concentration: 325000 nM
The estimate for compound 3 lay 2.6-fold (0.41 log units) below the measured number; measured number outside the range, above it.
By their numbers in this assay, from the lowest: compound 1; then compounds 2 and 3 (each within the scatter of the next).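

In this assay, benzamidomethyl and 4-(tert-butoxy)phenyl on this aromatic carbon cannot be told apart (a 1.6-fold higher number from compound 2 to compound 3 (0.21 log units; within the scatter)), even though benzamidomethyl brings a hydrogen-bond donor and a double bond outside aromatic rings that 4-(tert-butoxy)phenyl lacks. The comparison with 4-nitrophenyl does stand beyond the scatter (a 3.5-fold higher number from compound 1 to compound 3 (0.54 log units; beyond the scatter)), so compound 1 now differs from both other compounds by more than the scatter and holds the lowest number of the three, while the series shows no separation between compound 2 and compound 3. Nothing on hand gives a reason for either step, and the numbers alone cannot assign the gap to any feature of the groups that enter or leave.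

The compounds shown leave open how an amine, a carboxylic acid or a longer chain on this carbon would read in this assay, and whether any such group could bring the number below that of compound 1. They also leave open whether the amide hydrogen of benzamidomethyl matters, which an N-methyl amide in its place would test.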